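The source may report more compounds than this note shows. Statements on the series, on what has been measured and on what is new or still open speak of the compounds shown alone.

Compound 3 (`COc1cc(-c2cccc3nc(-c4cccc(Cl)c4)oc23)cc(OC)c1OC`) has in a functional assay on A549 cells (Homo sapiens) for antiproliferative activity, read by MTT assay, with a stated time of 48 h (a higher number here means a weaker inhibitor, a lower number a stronger inhibitor), only a limit (> 25000 nM) and no number. Compound 1 (`COc1cc(-c2cccc3nc(-c4ccccc4)oc23)cc(OC)c1OC`) gives 20300 nM there, and compound 2 (`COc1cc(-c2cccc3nc(-c4cccc(F)c4)oc23)cc(OC)c1OC`) gives 2600 nM in the same test. Hydroxy in place of chloro on an aromatic carbon, meta to a large group, leads to compound 4 (`COc1cc(-c2cccc3nc(-c4cccc(O)c4)oc23)cc(OC)c1OC`), with hydroxy in place of chloro on an aromatic carbon as the counted difference. Among the compounds with values here, no measured step makes this exchange, but three swaps on that same carbon bear on it. Fluoro for hydrogen gave a 7.8-fold lower number from compound 1 to compound 2 (0.89 log units; beyond the scatter) and chloro for hydrogen gave an at least 1.2-fold higher number from compound 1 to compound 3 (0.09 log units; that floor lies within the scatter) in the measurements. Chloro for fluoro gave an at least 9.6-fold higher number from compound 2 to compound 3 (0.98 log units; beyond the scatter) as the widest swing. On the size of that swing, a modest step toward a lower number is expected (an at least 2.7-fold lower number from compound 3 to compound 4 (0.44 log units; beyond the scatter)) here. For compound 4 the estimated value is 9000 nM with an expected range of 2000 nM to 30000 nM in this test.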

Compound 4, half-maximal inhibitory concentration: 2000 nM
Estimate against measurement, compound 4: 4.5-fold (0.65 log units) above; low and high end bracket the measured number.
By their numbers in this assay, from the lowest: compounds 4 and 2 (each within the scatter of the next); then compound 1. At a limit, above all of these: compound 3.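

In this assay, hydroxy is a second group on this carbon, after fluoro, that gives a clearly lower number than hydrogen: a 10-fold lower number from compound 1 to compound 4 (1.01 log units; beyond the scatter). Hydroxy and fluoro cannot be separated here (a 1.3-fold lower number from compound 2 to compound 4 (0.11 log units; within the scatter)), so chloro alone goes against this pattern: an at least 12-fold lower number from compound 3 to compound 4 (1.09 log units; beyond the scatter). That step starts from a limit and not from a number: the limit of > 25000 nM in this assay, at which 1 of the 4 values shown sits.

On these data alone, it remains open whether an amine or a carboxylic acid on this carbon would give a number like those of hydroxy and fluoro. As far as these compounds go, whether hydroxy would have the same effect on another carbon of this ring also remains open.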